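The compounds below may be only part of what the source reports. "The series", "measured", "known", "first", "only" and "open" are said of these compounds alone.

Working notes on the series. In an in vitro ADME assay on microsomes from liver (Homo sapiens) for metabolic stability (a higher number here means that the compound lasts longer, a lower number that the compound disappears faster), compound 1 (`CCOc1cccc2c1S(=O)(=O)N=C2C1=C(O)[C@H](C(C)C)N(Cc2ccccc2)C1=O`) gives > 1 h as a limit of the assay and not a number. Compound 2 (`CC(C)[C@H]1C(O)=C(C2=NS(=O)(=O)c3c(O)cccc32)C(=O)N1Cc1ccccc1`) gives > 1 h as a limit too. Compound 3 (`CC(C)[C@H]1C(O)=C(C2=NS(=O)(=O)c3c(OCC#N)cccc32)C(=O)N1Cc1ccccc1`) gives > 1 h as a limit as well. Compound 3 therefore has no number of its own and stands with the other two at the same limit (the limit of > 1 h in this assay, at which 3 of the 3 values shown sit).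

The next change leads to compound 4 (`CC(C)[C@H]1C(O)=C(C2=NS(=O)(=O)c3c(OCc4ncon4)cccc32)C(=O)N1Cc1ccccc1`), with 1,2,4-oxadiazol-3-yl in place of cyano on a saturated chain carbon bound to an oxygen on an aromatic ring. Going by the values given here, two measured steps bear on it, both ending at compound 3 and both made on that same oxygen (a step that the two limits leave unreadable from compound 1 to compound 3) (a step that the two limits leave unreadable from compound 2 to compound 3). Neither has a readable size, so neither gives a measured effect to carry over. Ethyl, hydrogen and cyanomethyl on that oxygen all leave the read-out at the limit, and none of the three compounds goes against this.

The estimated change is expected to be a step that the limit leaves unreadable from compound 3 to compound 4 in this measurement. The expectation rests on compound 3 and its limit of > 1 h and is therefore loose. Compound 4 is estimated at 1.5 h with an expected range from 0.7 h to 3.5 h for this measurement.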

Compound 4, half-life: > 1 h
Compound 4: no number, only a limit; the forecaster's own chance of this, stated with the estimate: 70%; the middle value lies beyond the limit too.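

Compound 4 also stands at a limit and not at a number, so the steps to it from compounds 1, 2 and 3 cannot be read: the limit of > 1 h in this assay, at which 4 of the 4 values shown sit.

The compounds shown leave open how long any of them lasts in this assay, and whether the group on the oxygen on the aromatic ring changes the half-life at all.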